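The compounds below may be only part of what the source reports. "The series", "measured", "known", "first", "only" and "open" are said of these compounds alone.

Among the measured compounds shown here, in an assay on brain for displacement of a labelled ligand from D(3) dopamine receptor (Rattus norvegicus) (a lower number here means a stronger inhibitor, a higher number a weaker inhibitor), compound 1 `CCCN(CC[C@H]1CC[C@H](NC(=O)/C=C/c2cccc(F)c2)CC1)[C@H]1CCc2nc(N)sc2C1` gives 9.9 nM, the highest of the two numbers measured so far. For the measured compounds named here, compound 2 `CCCN(CC[C@H]1CC[C@H](NC(=O)c2cccc3ncccc23)CC1)[C@H]1CCc2nc(N)sc2C1` gives 1.6 nM; the single measured step, a 6.2-fold lower number from compound 1 to compound 2 (0.79 log units; beyond the scatter), shows that exchanging the group on the carbonyl carbon for quinolin-5-yl brings the number down. Compound 3 `CCCN(CC[C@H]1CC[C@H](NC(=O)c2ccc(-n3ccnc3)cc2)CC1)[C@H]1CCc2nc(N)sc2C1` is not yet measured and carries a related change: 4-(1H-imidazol-1-yl)phenyl in place of 2-(3-fluorophenyl)ethenyl on a carbonyl carbon. That measured step bears on this one only loosely, since the entering group differs. For compound 3 a smaller step in the same direction is expected, a 2.8-fold lower number from compound 1 to compound 3 (0.45 log units; beyond the scatter). Compound 3 is therefore estimated at 3.5 nM, between 1 nM and 12 nM.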

Compound 3, inhibition constant: 1.9 nM
The estimate for compound 3 lay 1.8-fold (0.27 log units) above the measured number; low and high end bracket the measured number.
By their numbers in this assay, from the lowest: compounds 2 and 3 (each within the scatter of the next); then compound 1.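

Placed on the carbonyl carbon, 4-(1H-imidazol-1-yl)phenyl also lowers the number compared with 2-(3-fluorophenyl)ethenyl (a 5.2-fold lower number from compound 1 to compound 3 (0.72 log units; beyond the scatter)), so this drop is not confined to quinolin-5-yl. The two entering groups cannot be told apart here (a 1.2-fold higher number from compound 2 to compound 3 (0.07 log units; within the scatter)), even though quinolin-5-yl and 4-(1H-imidazol-1-yl)phenyl are different groups. No evidence is available to explain this result. Still open, on these data alone, is whether an unsubstituted phenyl, or a phenyl carrying an amine or a carboxylic acid in place of the imidazole, would stay at this level.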